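Swapping an Isopropyl for an Ester at a Chain Carbon

This account rests on a few compounds, and the source may have more. Where it says the series, first, only, none or still open, it means among the compounds named here.

Measured compounds:
compound 1, `COc1ccc(NC[C@H](C)NC(=O)[C@H](CC(C)C)NC(=O)c2cccc(C)c2)cc1`, 15 nM
compound 2, `COc1cccc(C(=O)N[C@@H](CCC2CCCCC2)C(=O)N[C@@H](CC(C)C)CN2CCc3cc(F)ccc32)c1`, 28 nM

Of the compounds shown here, two have been measured in an assay on isolated protein for inhibition of cathepsin S (Homo sapiens); on this read-out higher numbers stand for weaker inhibition and lower numbers for stronger inhibition. Compound 1 gives 15 nM and compound 2 gives 28 nM; these two numbers lie within the scatter of each other, so neither can be called the stronger inhibitor. Compound 2 is the point of departure for the next step.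

Compound 3, `CCOC(=O)C[C@@H](CN1CCc2cc(F)ccc21)NC(=O)[C@H](CCC1CCCCC1)NC(=O)c1cccc(OC)c1`, differs from compound 2 in one place: ethoxycarbonyl in place of isopropyl on a saturated chain carbon, two bonds along the chain from an amide-type nitrogen. Among the measured compounds shown here, no pair of measured compounds shows this kind of exchange, so there is no measured step to lean on; the expectation rests only on the two numbers above and on the nature of the change. A modest weakening is expected, of a size that may reach just beyond the scatter, though a result within it would not surprise. The expected step from compound 2 to compound 3 is a 2.1-fold higher number from compound 2 to compound 3 (0.33 log units; beyond the scatter). For compound 3 the estimate in this assay is 60 nM, with a range from 15 nM to 250 nM.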

Compound 3, inhibition constant: 16 nM
The estimate for compound 3 lay 3.8-fold (0.57 log units) above the measured number, and the stated range covers the measured number.
By their numbers in this assay, from the lowest: compounds 1, 3 and 2 (each within the scatter of the next).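

In this assay, putting ethoxycarbonyl in place of isopropyl on this saturated chain carbon gives a 1.8-fold lower number from compound 2 to compound 3 (0.24 log units; within the scatter), so compound 2 and compound 3 cannot be told apart. Among the compounds shown here, this is the first look at an exchange at this position, and it shows that a group of 5 heavy atoms with 2 hydrogen-bond acceptors can stand where a group of 3 heavy atoms with no acceptors stood, with no difference this read-out can resolve. Nothing measured here explains why the two groups give such similar numbers.

From the compounds shown here alone, how a carboxylic acid, an amine or a longer chain would read at the same carbon stays open. So does whether the exchange from isopropyl to ethoxycarbonyl would read the same way on a different core.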